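Swapping the amide aryl group for a small imidazole

A few compounds are considered here, and "the series" means these few. Any claim that something is new, unique, unknown or untested is made for them only; others in the source may bear on it.

Measured compounds:
- compound 1, `O=C(Nc1ccc(C(F)(F)F)cc1)c1cccc(Nc2ncc(F)c(Nc3ccc(F)cc3)n2)c1`: > 10000 nM in a functional assay on KB cells (Homo sapiens) for antiproliferative activity, read by sulforhodamine B assay, with a stated time of 3 days; on this read-out lower numbers stand for stronger inhibition of growth and higher numbers for weaker inhibition of growth
- compound 2, `O=C(c1cccc(Nc2ncc(F)c(Nc3ccc(F)cc3)n2)c1)N1CCCCC1`: 14800 nM
- compound 3, `CN1CCC(C(=O)Nc2cccc(Nc3ncc(F)c(Nc4ccc(F)cc4)n3)c2)CC1`: 1700 nM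

Three compounds share one core and differ only in the group hanging off the carbonyl on the outer benzene ring. Compound 1 reaches only the limit of this assay, so its value is a boundary rather than a number, and the limit of > 10000 nM in this assay, at which 1 of the 3 values shown sits, marks where it sits. Compound 2 carries a plain piperidine on the carbonyl, and the step that the limit leaves unreadable from compound 1 to compound 2 cannot be sized. Compound 3 turns the amide around and adds a methyl on the piperidine nitrogen, giving an 8.7-fold lower number from compound 2 to compound 3 (0.94 log units; beyond the scatter).

Compound 4, `Cn1ccnc1NC(=O)c1cccc(Nc2ncc(F)c(Nc3ccc(F)cc3)n2)c1`, keeps the amide of compound 1 but changes its substituent: 1-methyl-1H-imidazol-2-yl in place of 4-(trifluoromethyl)phenyl on an amide-type nitrogen. Among the measured compounds shown here, none of the measured steps touches this position in the same way, so no direct guide exists; the only readable step, an 8.7-fold lower number from compound 2 to compound 3 (0.94 log units; beyond the scatter), concerns a different part of the amide. Starting from a limit, the expectation for compound 4 is a modest move toward a measurable number, an at least 1.2-fold lower number from compound 1 to compound 4 (0.09 log units; that floor lies within the scatter), with wide uncertainty. The estimate for compound 4 in this assay is 8000 nM, between 2000 nM and 30000 nM.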

Compound 4, concentration for 50% growth inhibition: 14600 nM
Beside the measured number, compound 4's estimate is 1.8-fold (0.26 log units) below it; measured number inside the range.
By their numbers in this assay, from the lowest: compound 3; then compounds 4 and 2 (each within the scatter of the next).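

Compound 1 in this assay is given only as a limit, so the change from 4-(trifluoromethyl)phenyl to 1-methyl-1H-imidazol-2-yl on the amide-type nitrogen cannot be read as a step, and its size remains unknown: the limit of > 10000 nM in this assay, at which 1 of the 4 values shown sits.

The new number can still be set against the other two compounds, and the first comparison is with the piperidine amide: a 1.0-fold lower number from compound 2 to compound 4 (0.01 log units; within the scatter). On the carbonyl carbon, (1-methyl-1H-imidazol-2-yl)amino and piperidin-1-yl therefore cannot be told apart in this assay, while the second comparison shows that the imidazole does not reach the level of the compound carrying the turned-around amide: an 8.6-fold higher number from compound 3 to compound 4 (0.93 log units; beyond the scatter).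

The compounds shown leave open whether any group on this amide-type nitrogen can bring the number down to that of compound 3, such as a chain ending in an amine or a carboxylic acid. They also leave open what the methyl on the imidazole contributes, which a plain 1H-imidazol-2-yl group on the same nitrogen would help to answer.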